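This account rests on a few compounds, and the source may have more. Where it says the series, first, only, none or still open, it means among the compounds named here.

Measured compounds:
compound 1 `COc1cc2nccc(Oc3ccc(NC(=O)c4ncc(-c5ccc(F)cc5)o4)cc3)c2cc1OC` with 5590 nM
compound 2 `COc1cc2c(Oc3ccc(NC(=O)c4nnc(-c5ccc(F)cc5)o4)cc3)ccnc2cc1OCCCN1CCC(C)CC1` with 2730 nM

In a functional assay on A549 cells (Homo sapiens) for antiproliferative activity, read by MTT assay, with a stated time of 72 h (a lower number here means a stronger inhibitor, a higher number a weaker inhibitor), compound 1 gives 5590 nM. Compound 2 stands at the lower of the two numbers in this assay, with 2730 nM, and its nearest neighbour is compound 1, whose number is higher by a margin that goes beyond the scatter. Among the measured compounds shown here, compound 1 and compound 2 differ in more than one place, so their two values show only that compound 2 is the stronger inhibitor of the pair.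

Compound 3 `COc1cc2c(Oc3ccc(NC(=O)c4ncc(-c5ccc(F)cc5)o4)cc3)ccnc2cc1OCCCN1CCC(C)CC1` has not yet been measured in this assay. It differs from compound 2 in one place: 5-(4-fluorophenyl)-1,3-oxazol-2-yl in place of 5-(4-fluorophenyl)-1,3,4-oxadiazol-2-yl on a carbonyl carbon. The shared core and the chain on it are kept, and the ring that sits on the carbonyl carbon changes. For the measured compounds named here, no single step of this kind between two measured compounds is available, so the direction of the change can only be guessed. For compound 3 a small step is expected, a 1.3-fold higher number from compound 2 to compound 3 (0.11 log units; within the scatter), probably not beyond the scatter, and perhaps toward a slightly higher number. Compound 3 is estimated at 3500 nM, within a range from 1200 nM to 10000 nM.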

Compound 3, half-maximal inhibitory concentration: 240 nM
Compound 3: middle estimate off by 15-fold (1.16 log units), on the high side; measured number below the stated range.
By their numbers in this assay, from the lowest: compound 3; then compound 2; then compound 1.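

In this assay, the ring on the carbonyl carbon proves to be a sensitive place: 5-(4-fluorophenyl)-1,3-oxazol-2-yl in place of 5-(4-fluorophenyl)-1,3,4-oxadiazol-2-yl gives an 11-fold lower number from compound 2 to compound 3 (1.06 log units; beyond the scatter), although the heavy-atom count stays the same and the five-membered ring carries one hetero atom fewer. The chain can now also be read on its own, which the earlier pair did not allow: 2-(4-methylpiperidin-1-yl)ethyl in place of hydrogen on a saturated chain carbon bound to an oxygen on an aromatic ring gives a 23-fold lower number from compound 1 to compound 3 (1.37 log units; beyond the scatter). Both steps end at compound 3, so each is read only with the other part as it stands there, and the chain step remains unread with the 5-(4-fluorophenyl)-1,3,4-oxadiazol-2-yl group in place.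

Nothing at hand accounts for the size of either step.

The compounds shown leave open whether a morpholine in place of the 4-methylpiperidine, a longer chain, or a chlorine in place of the fluorine on the six-membered ring would hold, raise or lower the number seen for compound 3.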